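The compounds below may be only part of what the source reports. "The series", "measured", "known", "first", "only" and "open" are said of these compounds alone.

Measured compounds:
- compound 1 `ClCc1cccc(Cn2cnc3ncnc(Cl)c32)c1`: 15100 nM
- compound 2 `ClCc1cccc(Cn2cnc3c(Cl)ncnc32)c1`: 11200 nM

Both numbers come from a functional assay on DU-145 cells (Homo sapiens) for cytotoxicity, read by sulforhodamine B assay, with a stated time of 48 h; on this read-out higher numbers stand for weaker inhibition of growth and lower numbers for stronger inhibition of growth. In this assay compound 2 gives 11200 nM, and compound 1 at 15100 nM lies within the usual scatter of that figure, so the two cannot be told apart on these data. Within the data shown here, compound 2 therefore stands at the same level as the only other measured compound, and both are weak inhibitors of growth in this assay.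

Compound 3 `ClCc1cccc(Cn2cnc3c(Cl)nc(Cl)nc32)c1` has not been measured. It differs from compound 2 in one place: chloro in place of hydrogen on an aromatic carbon. Among the measured compounds shown here, no measured pair shows this change, so its effect can only be guessed. Given that the two measured compounds sit close together and both at the weak end, the expectation is for a small step, not clearly beyond the scatter, with at most a slight lowering of the number. On that basis the step from compound 2 to compound 3 is estimated at a 1.4-fold lower number from compound 2 to compound 3 (0.15 log units; within the scatter). Compound 3 is expected to give about 8000 nM in this assay, with a range from 2500 nM to 25000 nM.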

Compound 3, concentration for 50% growth inhibition: 1580 nM
The estimate for compound 3 lay 5.1-fold (0.70 log units) above the measured number; measured number outside the range, below it.
By their numbers in this assay, from the lowest: compound 3; then compounds 2 and 1 (each within the scatter of the next).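

In this assay, among these compounds, chloro in place of hydrogen on the aromatic carbon between two ring nitrogen atoms gives a 7.1-fold lower number from compound 2 to compound 3 (0.85 log units; beyond the scatter) and is the first step to clear the scatter. This carbon is therefore a place where a change of a single heavy atom, with no ring, no hydrogen-bond donor or acceptor and no net charge, can shift growth inhibition in these cells. The step is still modest, and compound 3 at 1580 nM remains a micromolar-range entry on the printed value, so the position is responsive but the series has not yet reached high potency. No measurement at hand speaks to the reason for this step.

On these data alone, whether an amine or a methoxy group on this carbon would act as chloro does remains open, as does whether the step depends on the chloro group that lies meta to it in compound 3. What a hydroxymethyl group or a carboxylic acid would do in place of the chloromethyl group, common to all the compounds shown, is equally open.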